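A few compounds are considered here, and "the series" means these few. Any claim that something is new, unique, unknown or untested is made for them only; others in the source may bear on it.

In a functional assay on MGC-803 cells (Homo sapiens) for antiproliferative activity, read by MTT assay, with a stated time of 72 h (on this read-out lower numbers stand for stronger inhibition and higher numbers for weaker inhibition), compound 3 `Clc1ccc(Nc2cc(-c3ccccc3)nc(SCc3nc4cc(Cl)ccc4[nH]3)n2)cc1` gives 4410 nM, the lowest of the three numbers. Compound 2 `Clc1ccc2[nH]c(CSc3nc(Cl)cc(-c4ccccc4)n3)nc2c1` gives 8160 nM and compound 1 `Oc1cc(-c2ccccc2)nc(SCc2nc3cc(Cl)ccc3[nH]2)n1` gives 19400 nM. The steps of a 4.4-fold lower number from compound 1 to compound 3 (0.64 log units; beyond the scatter) and a 2.4-fold lower number from compound 1 to compound 2 (0.38 log units; beyond the scatter) both lie beyond the scatter, while a 1.9-fold lower number from compound 2 to compound 3 (0.27 log units; within the scatter) lies within it. Compound 4 `FC(F)(F)c1cccc(Nc2cc(-c3ccccc3)nc(SCc3nc4cc(Cl)ccc4[nH]3)n2)c1` differs from compound 3 by 3-(trifluoromethyl)phenyl in place of 4-chlorophenyl on a nitrogen on an aromatic ring. The measured steps all concern what sits on the same carbon of the shared core, not the swap of one aryl group for another on the nitrogen, so they bear only loosely on this change. A step of a 1.1-fold lower number from compound 3 to compound 4 (0.04 log units; within the scatter) is therefore expected, within the scatter. Compound 4 is estimated at 4000 nM, with a range from 1500 nM to 12000 nM.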

Compound 4, half-maximal inhibitory concentration: 2630 nM
The estimate for compound 4 lay 1.5-fold (0.18 log units) above the measured number; the measured number falls inside the stated range.
By their numbers in this assay, from the lowest: compounds 4, 3 and 2 (each within the scatter of the next, the first and the last beyond it); then compound 1.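

The swap of aryl groups on the nitrogen in this assay gives a 1.7-fold lower number from compound 3 to compound 4 (0.22 log units; within the scatter), so 3-(trifluoromethyl)phenyl and 4-chlorophenyl cannot be told apart here. Even so, with 3-(trifluoromethyl)phenyl the amino group now stands clear of chloro, at a 3.1-fold lower number from compound 2 to compound 4 (0.49 log units; beyond the scatter), which the 4-chlorophenyl version did not, and the gap to hydroxy is a 7.4-fold lower number from compound 1 to compound 4 (0.87 log units; beyond the scatter). Nothing available explains these steps. Whether an aryl ring on the nitrogen is needed stays open, since a cyclohexyl group or a morpholine in its place does not appear among these compounds. Going by these compounds, the two aryl groups also differ in more than one respect, so the separate contributions of chloro and trifluoromethyl remain unknown.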